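A few compounds are considered here, and "the series" means these few. Any claim that something is new, unique, unknown or untested is made for them only; others in the source may bear on it.

Measured so far:
compound 1 `CC1CCC(C(=O)N2CC(c3nc(-c4cccc(Cl)c4)no3)C2)CC1` — 1500 nM
compound 2 `Cc1ccc(S(=O)(=O)N2CC(c3nc(-c4cccc(Cl)c4)no3)C2)cc1` — > 10000 nM

Among the compounds with values here, compound 1 `CC1CCC(C(=O)N2CC(c3nc(-c4cccc(Cl)c4)no3)C2)CC1` holds the only plain number in an assay on HEK293 cells for positive allosteric modulation of metabotropic glutamate receptor 5 (Homo sapiens), read by FLIPR; on this read-out lower numbers stand for an effect already at smaller amounts and higher numbers for an effect only at larger amounts of compound: compound 1 gives 1500 nM. Compound 2 `Cc1ccc(S(=O)(=O)N2CC(c3nc(-c4cccc(Cl)c4)no3)C2)cc1` reaches only a limit of this assay, > 10000 nM, so no number is known for compound 2. That limit is the limit of > 10000 nM in this assay, at which 1 of the 2 values shown sits. Compound 3 `COC1CCCN(C(=O)N2CC(c3nc(-c4cccc(Cl)c4)no3)C2)C1` has not been measured yet. It differs from compound 1 in one place: 3-methoxypiperidin-1-yl in place of 4-methylcyclohexyl on a carbonyl carbon. Within the data shown here, no two measured compounds differ in just one place, so there is no measured step to lean on, and the limit of compound 2 gives no size either. The step expected is a 2.0-fold higher number from compound 1 to compound 3 (0.30 log units; within the scatter), a modest shift toward larger amounts of compound that may still sit inside the usual scatter. Compound 3 is expected to give about 3000 nM, with a range from 900 nM to 12000 nM.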

Compound 3, half-maximal effective concentration: > 10000 nM
Compound 3: no number, only a limit (the forecaster's own chance of this, stated with the estimate: 30%); at least 3.3-fold (0.52 log units) between middle value and limit.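

The carbonyl carbon now has its first direct comparison in this assay: 3-methoxypiperidin-1-yl in place of 4-methylcyclohexyl gives an at least 6.6-fold higher number from compound 1 to compound 3 (0.82 log units; beyond the scatter). So at this position, one six-membered non-aromatic ring cannot simply be exchanged for another, even though the two groups are close in heavy-atom count and neither carries a net charge. Compound 3 gives only a limit of the assay, > 10000 nM, not a number, so the step has a floor but no known full size: the limit of > 10000 nM in this assay, at which 2 of the 3 values shown sit.

The entering group differs in two ways at once, through its ring nitrogen and through its methoxy group, and the compounds shown do not tell which of these matters. A plain piperidin-1-yl or a methoxycyclohexyl on the same carbonyl carbon would pull the two apart.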